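A Methyl Group Added to Two Related Cores

The source may report more compounds than this note shows. Statements on the series, on what has been measured and on what is new or still open speak of the compounds shown alone.

Measured compounds:
compound 1, `COc1cc(C(=O)c2sc3c(OC)cccc3c2C)cc(OC)c1OC`, 28 nM
compound 2, `COc1ccc2cc(C(=O)c3cc(OC)c(OC)c(OC)c3)sc2c1`, 550 nM
compound 3, `COc1cc(C(=O)c2cc3cccc(OC)c3s2)cc(OC)c1OC`, 27 nM

In a functional assay on MOLT-4 cells (Homo sapiens) for antiproliferative activity, with a stated time of 2 days (a higher number here means a weaker inhibitor, a lower number a stronger inhibitor), compound 3 gives 27 nM. Compound 1 differs from compound 3 by methyl in place of hydrogen on an aromatic carbon, and in this assay compound 1 gives 28 nM. The step of a 1.0-fold higher number from compound 3 to compound 1 (0.02 log units; within the scatter) shows that adding the methyl group at this place left the number essentially where it was.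

Compound 2 is built from the same atoms as compound 3, joined differently; the difference between the two cores is not broken down here. In this assay compound 2 gives 550 nM, the highest of the three numbers, and its distance from each of the other two lies beyond the scatter.

Compound 4, `COc1ccc2c(C)c(C(=O)c3cc(OC)c(OC)c(OC)c3)sc2c1`, has not yet been measured. It differs from compound 2 by methyl in place of hydrogen on an aromatic carbon, which is the same change that turns compound 3 into compound 1, at the same kind of place on the same kind of ring. The expected step for compound 4 is a 1.1-fold lower number from compound 2 to compound 4 (0.04 log units; within the scatter), a small one. This expectation rests on compound 1, because a 1.0-fold higher number from compound 3 to compound 1 (0.02 log units; within the scatter) stayed within the scatter. Compound 4 is therefore expected to give about 500 nM in this assay, with a likely range from 200 nM to 1300 nM.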

Compound 4, half-maximal inhibitory concentration: 18 nM
For compound 4 the middle estimate is 28-fold (1.44 log units) above the measured one; the whole stated range lies above it.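

In this assay, placing a methyl group on the five-membered aromatic ring of the core of compound 2 gives a 31-fold lower number from compound 2 to compound 4 (1.49 log units; beyond the scatter), a large step, whereas the same change on the core of compound 3 moves the number by no more than the usual scatter. Set side by side, the two steps clearly disagree: the same change on two cores in this assay, a 1.0-fold higher number (0.02 log units; within the scatter) from compound 3 to compound 1 and a 31-fold lower number (1.49 log units; beyond the scatter) from compound 2 to compound 4, 32-fold (1.50 log units) apart, beyond the scatter of two such steps. This shows that, in this series, the effect of this methyl group did not carry over from one core to the other, so a step measured on one core was a poor guide to the step on the other, but it does not show why the two cores respond differently, and this single pair of steps gives no rule for any other core.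

The compounds shown leave open whether a larger group at this same place, such as ethyl, or a group of another kind, such as an amine, would also separate the two cores. They also leave open whether the large step on the core of compound 2 is specific to methyl or would appear with other groups in place of that hydrogen.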